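An Ethyl Group on a Compound at the Limit

The source may report more compounds than this note shows. Statements on the series, on what has been measured and on what is new or still open speak of the compounds shown alone.

Compound 2 (`Cc1cccc(C(=O)N[C@@H]2C(=O)Nc3c(c(C)nn3-c3ccccc3)[C@@H]2c2ccc(F)cc2)c1`) gives > 25000 nM in an ADME assay on HCC95 cells (Homo sapiens) for inhibition, read by CellTiter-Glo, with a stated time of 72 h (on this read-out higher numbers stand for an effect only at larger amounts of compound and lower numbers for an effect already at smaller amounts), as a limit of the assay, not a number. Compound 1 (`CCCn1nc(C)c2c1N(CC)C(=O)[C@@H](NC(=O)c1cccc(C)c1)[C@H]2c1ccc(F)cc1`) gives > 25000 nM in this assay as a limit too. So the limit of > 25000 nM in this assay, at which 2 of the 2 values shown sit, is where compound 2 stands. Compound 3 (`CCN1C(=O)[C@@H](NC(=O)c2cccc(C)c2)[C@@H](c2ccc(F)cc2)c2c(C)nn(-c3ccccc3)c21`) differs from compound 2 by ethyl in place of hydrogen on an amide-type nitrogen in a ring and carries ethyl in place of hydrogen on an amide-type nitrogen in a ring. Among the measured compounds shown here, no measured step shows what this change does. The estimated step of a number no higher from compound 2 to compound 3 (the limit leaves the size open) stays within the usual scatter in this assay with no favoured direction. For compound 3 the estimated value is 25000 nM with an expected range of 12000 nM to 50000 nM on this read-out.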

Compound 3, half-maximal effective concentration: > 25000 nM
Compound 3 gave a limit, no number; the forecaster's own chance of this, stated with the estimate: 85%; the middle value sits exactly at the limit.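

Compound 3 gives > 25000 nM, a limit and not a number, so its steps from compound 1 and compound 2, both limits too, cannot be read. The compounds shown leave open what ethyl in place of hydrogen, or phenyl in place of propyl, does in this assay.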